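The compounds below may be only part of what the source reports. "The series", "measured", "known", "first", "only" and "open" are said of these compounds alone.

Working notes on the series. The parent pair share one fused core. Compound 1 `Cc1c(CO)c(CO)c2n1[C@@H](c1ccccc1)SC2` carries a methyl on the aromatic ring of that core; in a functional assay on MCF7 cells (Homo sapiens) for cytotoxicity, read by MTT assay, with a stated time of 72 h (a higher number here means a weaker inhibitor, a lower number a stronger inhibitor), compound 1 gives 1000 nM. Compound 2 `OCc1cn2c(c1CO)CS[C@@H]2c1ccccc1` lacks that methyl, and in this assay compound 2 gives "not determined" (no result reported), so compound 2 stands on no number at all within this set; the only measured point in the series is compound 1.

Compound 3 `OCc1cn2c(c1CO)CS[C@@H]2c1cccnc1` is the analogue of compound 2 in which (pyridin-3-yl in place of phenyl on a saturated ring carbon). Among the compounds with values here, no measured pair shows this kind of change, so the direction of any step in this assay is open; a shift beyond the scatter in either sense cannot be excluded, and a step within the scatter is as plausible as any other outcome.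

With compound 1 as the sole anchor, compound 3 is expected to land near 1500 nM, within a range of 400 nM to 6000 nM.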

Compound 3, half-maximal inhibitory concentration: 61700 nM
Compound 3: the middle estimate sits 41-fold (1.61 log units) below what was measured; measured number outside the range, above it.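

Within the data shown here, no step from compound 2 to compound 3 can be read, as compound 2 has no number in this assay. The compounds shown leave open how replacing phenyl with pyridin-3-yl shifts this assay. No supporting data bear on the value of compound 3.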